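This account rests on a few compounds, and the source may have more. Where it says the series, first, only, none or still open, it means among the compounds named here.

Measured compounds and their values:
Compound 1 `Nc1nc(C(F)(F)F)cc2c1[nH]c(=O)n2Cc1ccc(NCCN2CCCCC2)nc1` gives 16 mL.min-1.g-1 in an in vitro ADME assay on microsomes from liver (Rattus norvegicus) for pharmacokinetics; on this read-out higher numbers stand for fast clearance and lower numbers for slow clearance.
Compound 2 `Nc1nc(C(F)(F)F)cc2c1[nH]c(=O)n2Cc1ccc(NCCN2CCCC2)nc1` gives only a limit of the assay, < 8.5 mL.min-1.g-1, in this assay.
Compound 3 `CN1CCN(c2ccc(Cn3c(=O)[nH]c4c(N)nc(C(F)(F)F)cc43)cn2)CC1` gives 46 mL.min-1.g-1 in this assay.

Among the numbers shown, compound 1 stands lowest; its nearest neighbour is compound 3, reached by a step of a 2.9-fold higher number from compound 1 to compound 3 (0.46 log units; beyond the scatter). Compound 2 sits at the limit (the limit of < 8.5 mL.min-1.g-1 in this assay, at which 1 of the 3 values shown sits), and the step of an at least 1.8-fold lower number from compound 1 to compound 2 (0.27 log units; that floor lies within the scatter) therefore cannot be placed more exactly.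

Compound 4 `Nc1nc(C(F)(F)F)cc2c1[nH]c(=O)n2Cc1ccc(NCCO)nc1` is the next compound to be measured. It differs from compound 1 in one place: hydroxy in place of piperidin-1-yl on a saturated chain carbon, two bonds along the chain from a nitrogen on an aromatic ring. Within the data shown here, two measured steps bear on this. The exchange of piperidin-1-yl for pyrrolidin-1-yl at the same chain carbon gave an at least 1.8-fold lower number from compound 1 to compound 2 (0.27 log units; that floor lies within the scatter), a small change at best. The exchange of the whole (2-(piperidin-1-yl)ethyl)amino group for 4-methylpiperazin-1-yl on the aromatic carbon gave a 2.9-fold higher number from compound 1 to compound 3 (0.46 log units; beyond the scatter). Neither step removes the ring altogether and leaves a hydroxy, so the change to compound 4 goes further than anything measured. In this assay a step of about a 1.3-fold lower number from compound 1 to compound 4 (0.12 log units; within the scatter) is expected, toward a lower number, though such a step would not clearly exceed the scatter. Compound 4 is therefore estimated at 12 mL.min-1.g-1, with a likely range from 6 mL.min-1.g-1 to 28 mL.min-1.g-1.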

Compound 4, intrinsic clearance in microsomes: < 8.5 mL.min-1.g-1
Compound 4 was reported as a limit; the forecaster's own chance of this, stated with the estimate: 35%; at least 1.4-fold (0.14 log units) between middle value and limit.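

In this assay, hydroxy on the saturated chain carbon removes the piperidin-1-yl ring altogether, and the result is an at least 1.8-fold lower number from compound 1 to compound 4 (0.27 log units; that floor lies within the scatter), so losing the ring at this position does not raise the number, although the size of the drop cannot be separated from the scatter. The comparison with compound 3 is clearer, at an at least 5.4-fold lower number from compound 3 to compound 4 (0.73 log units; beyond the scatter): the (2-hydroxyethyl)amino group lies on the slow-clearance side of 4-methylpiperazin-1-yl by more than the scatter. Compound 4 joins compound 2 at a limit of the assay, so the step between them cannot be read and hydroxy and pyrrolidin-1-yl cannot be ranked against each other: the limit of < 8.5 mL.min-1.g-1 in this assay, at which 2 of the 4 values shown sit.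

As far as these compounds go, how far compound 2 and compound 4 lie under that limit stays unknown, so the true size of the gain in going from piperidin-1-yl to either group also stays open. Equally open, from the compounds shown here alone, is whether a methoxy group or a dimethylamino group on the same chain carbon would stay at the limit or climb back toward compound 1, and whether a longer chain ending in hydroxy would behave like compound 4.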